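Pyridin-2-yl for phenyl on the carbonyl carbon of compound 3

The compounds below may be only part of what the source reports. "The series", "measured", "known", "first", "only" and "open" are said of these compounds alone.

Three members of the series carry a measured number in an assay on Sf21 cells for inhibition of cytochrome c oxidase subunit 2 (Homo sapiens), read by spectrophotometry, with a stated time of 5 min; on this read-out lower numbers stand for stronger inhibition and higher numbers for weaker inhibition. Compound 1 `COc1ccc(C(=O)CC2CC(=O)N(c3ccc(S(N)(=O)=O)cc3)C2=O)cc1` gives 2100 nM in this assay. Compound 2 `NS(=O)(=O)c1ccc(N2C(=O)CC(C3CCCCCC3=O)C2=O)cc1` gives 20700 nM in this assay. Compound 3 `NS(=O)(=O)c1ccc(N2C(=O)CC(CC(=O)c3ccccc3)C2=O)cc1` gives 4230 nM in this assay, the second highest of the three numbers: the step of a 2.0-fold higher number from compound 1 to compound 3 (0.30 log units; within the scatter) lies within the scatter, while the number of compound 2 stands beyond the scatter above that of compound 3.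

Compound 4 `NS(=O)(=O)c1ccc(N2C(=O)CC(CC(=O)c3ccccn3)C2=O)cc1` differs from compound 3 in one place: pyridin-2-yl in place of phenyl on a carbonyl carbon. Among the measured compounds shown here, the only single-point step measured so far, a 2.0-fold higher number from compound 1 to compound 3 (0.30 log units; within the scatter), concerns a substituent on the aromatic ring that sits on the carbonyl carbon and stayed within the scatter; no measured step exchanges a ring atom of that aromatic ring for a hetero atom. On that basis no step beyond the scatter is expected in this assay, in either direction. Compound 4 is estimated at 4200 nM, with a range from 1500 nM to 12000 nM, the expected step being a 1.0-fold lower number from compound 3 to compound 4 (0.00 log units; within the scatter).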

Compound 4, half-maximal inhibitory concentration: 8940 nM
Beside the measured number, compound 4's estimate is 2.1-fold (0.33 log units) below it; the measured number falls inside the stated range.
By their numbers in this assay, from the lowest: compounds 1 and 3 (each within the scatter of the next); then compound 4; then compound 2.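

In this assay, exchanging a ring carbon for nitrogen in the aromatic ring on the carbonyl carbon gives a 2.1-fold higher number from compound 3 to compound 4 (0.32 log units; beyond the scatter), so this ring responds to a change that the methoxy step, which stayed within the scatter, did not reveal. Measured against the 4-methoxyphenyl group, pyridin-2-yl gives a 4.3-fold higher number from compound 1 to compound 4 (0.63 log units; beyond the scatter), so both comparisons with a carbon-only ring run towards weaker inhibition, though both steps are modest. Nothing available here explains the shift.

Pyridin-3-yl and pyridin-4-yl would show whether the result depends on where the ring nitrogen stands, and a methoxy group on the pyridin-2-yl ring would show whether that substituent reads differently there. Going by these compounds, whether a five-membered ring such as thiazol-2-yl on the carbonyl carbon follows pyridin-2-yl also remains open.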